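The compounds below may be only part of what the source reports. "The series", "measured", "known", "first", "only" and "open" are said of these compounds alone.

Measured so far in a functional assay for agonist activity at G protein-coupled receptor 88 (Homo sapiens), read by HTRF and cAMP accumulation; on this read-out lower numbers stand for an effect already at smaller amounts and higher numbers for an effect only at larger amounts of compound:
compound 1 `CC(C)C[C@@H](N)CN(C(=O)[C@@H]1C[C@H]1c1ccccc1)c1ccc(-c2ccccc2)cc1` with 1.8 nM
compound 2 `CC[C@@H](C)[C@H](N)CN(C(=O)[C@@H]1C[C@H]1c1ccccc1)c1ccc(-c2ccccc2)cc1` with 1.4 nM
compound 3 `O=C([C@@H]1C[C@H]1c1ccccc1)N(CC1CCCNC1)c1ccc(-c2ccccc2)cc1` with 10 nM

Among these three, compound 1 stands second highest. Its nearest neighbour is compound 2, separated by a 1.3-fold lower number from compound 1 to compound 2 (0.11 log units; within the scatter), a gap within the scatter, while compound 3 lies furthest off, with a 5.6-fold higher number from compound 1 to compound 3 (0.74 log units; beyond the scatter).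

Compound 4 `O=C([C@@H]1C[C@H]1c1ccccc1)N(CCNCC1CCCCC1)c1ccc(-c2ccccc2)cc1` has not yet been measured. It differs from compound 1 in one place: ((cyclohexylmethyl)amino)methyl in place of 1-amino-3-methylbutyl on a saturated chain carbon bound to an amide-type nitrogen. Cut one bond further out, the change reads 2-amino-4-methylpentyl to 2-((cyclohexylmethyl)amino)ethyl.

Two kinds of measured step bear on this. The swap of 1-amino-2-methylbutyl for 1-amino-3-methylbutyl, a 1.3-fold lower number from compound 1 to compound 2 (0.11 log units; within the scatter), shows that reshaping the branched chain while leaving its nitrogen untouched changes nothing beyond the scatter. The replacement by piperidin-3-yl, a 5.6-fold higher number from compound 1 to compound 3 (0.74 log units; beyond the scatter), with the matching a 7.1-fold higher number from compound 2 to compound 3 (0.85 log units; beyond the scatter), shows that a nitrogen no longer standing free at the chain end, but built into a ring, goes with a modest loss. In compound 4 the nitrogen again stands no longer free but carries a cyclohexylmethyl, so a modest rise of similar order is expected for compound 4: a 4.4-fold higher number from compound 1 to compound 4 (0.65 log units; beyond the scatter). Compound 4 is therefore estimated at 8 nM, within a range from 2.5 nM to 30 nM.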

Compound 4, half-maximal effective concentration: 6.6 nM
Beside the measured number, compound 4's estimate is 1.2-fold (0.08 log units) above it; measured number inside the range.
By their numbers in this assay, from the lowest: compounds 2 and 1 (each within the scatter of the next); then compounds 4 and 3 (each within the scatter of the next).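

In this assay, the open-chain ((cyclohexylmethyl)amino)methyl group, with more heavy atoms than 1-amino-3-methylbutyl, a six-membered non-aromatic ring of carbon only and no defined stereocentre, gives a 3.7-fold higher number from compound 1 to compound 4 (0.56 log units; beyond the scatter) and, against the other branched chain, a 4.7-fold higher number from compound 2 to compound 4 (0.67 log units; beyond the scatter) as modest steps beyond the scatter. Set against piperidin-3-yl, the same group gives a 1.5-fold lower number from compound 3 to compound 4 (0.18 log units; within the scatter) and so cannot be told apart from it, which shows that the modest loss at this saturated chain carbon bound to an amide-type nitrogen is not confined to a nitrogen built into a ring. The larger group thus costs no more here than piperidin-3-yl does, even though its nitrogen stands in an open chain and carries a cyclohexylmethyl.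

The change removes the branch and the stereocentre and adds the cyclohexylmethyl at once, so the compounds shown leave open how a plain 2-aminoethyl chain, or a single methyl on the nitrogen of the 1-amino-3-methylbutyl group, would read on its own. Nothing at hand explains why the substituted nitrogen goes with this modest loss.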